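The source may hold more compounds than are shown below. What is called first, only, known or untested is meant among the compounds shown, and "the series" means these compounds.

For the measured compounds named here, in a functional assay on MDA-MB-231 cells (Homo sapiens) for cytotoxicity, read by MTT assay, with a stated time of 72 h (on this read-out lower numbers stand for stronger inhibition and higher numbers for weaker inhibition), compound 3 `CN(C)CCNc1nc(-c2ccc(NC(=O)Nc3ccc(F)cc3)cc2)nc2ccsc12` gives 540 nM, the lowest of the three numbers measured so far. The nearest number belongs to compound 1 `CN(C)CCCNc1nc(-c2ccc(NC(=O)Nc3ccc(F)cc3)cc2)nc2c(Cl)c(Cl)sc12`, which gives 980 nM; that gap lies within the usual scatter, so the two cannot be ranked. The furthest belongs to compound 2 `CN(C)CCCNc1nc(-c2ccc(NC(=O)Nc3ccc(Cl)cc3Cl)cc2)nc2c(Cl)c(Cl)sc12`, which gives 3490 nM.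

Compound 4 `CN(C)CCNc1nc(-c2ccc(NC(=O)Nc3ccc(Cl)cc3Cl)cc2)nc2ccsc12` differs from compound 3 by a single change: 2,4-dichlorophenyl in place of 4-fluorophenyl on an amide-type nitrogen. Going by the values given here, one measured step bears directly on this. Compounds 1 and 2 differ in exactly the same way, on a related core, and there the change gave a 3.6-fold higher number from compound 1 to compound 2 (0.55 log units; beyond the scatter), a weakening beyond the scatter. Among the compounds with values here, with only that one pair to go on, a step of similar size and the same direction is expected here, with some room for the cores to behave differently.

Compound 4 is therefore estimated to give 1950 nM in this assay, within a range of 900 nM to 4500 nM, which would mean a step of a 3.6-fold higher number from compound 3 to compound 4 (0.56 log units; beyond the scatter).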

Compound 4, half-maximal inhibitory concentration: 2450 nM
Compound 4: middle estimate off by 1.3-fold (0.10 log units), on the low side; low and high end bracket the measured number.
By their numbers in this assay, from the lowest: compounds 3 and 1 (each within the scatter of the next); then compounds 4 and 2 (each within the scatter of the next).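

The step of a 4.5-fold higher number from compound 3 to compound 4 (0.66 log units; beyond the scatter) shows that the weakening seen earlier on going from 4-fluorophenyl to 2,4-dichlorophenyl on the amide-type nitrogen is not confined to a single core. In each pair, this is the only difference, and the compound with 4-fluorophenyl gives the lower number. The size of the change also holds steady in this assay: the same change on two cores in this assay, a 3.6-fold higher number (0.55 log units; beyond the scatter) from compound 1 to compound 2 and a 4.5-fold higher number (0.66 log units; beyond the scatter) from compound 3 to compound 4, 1.3-fold (0.11 log units) apart, within the scatter of two such steps.

The swap removes the fluorine and brings in two chlorines at once, so these compounds cannot show which part of the change matters. A plain phenyl or a 4-chlorophenyl group on the same nitrogen would help separate these parts, and a 2-chlorophenyl group would show what a chlorine at that ring position does alone.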